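A few compounds are considered here, and "the series" means these few. Any claim that something is new, unique, unknown or untested is made for them only; others in the source may bear on it.

Within the data shown here, in a physicochemical assay for lipophilicity, read by HPLC, measured as chromatographic lipophilicity, at pH 7.4 (on this read-out lower numbers stand for lower lipophilicity and higher numbers for higher lipophilicity), compound 2 `O=C(C1CCCCC1)N1N=CCC1c1ccccc1` gives 5.9, the higher of the two numbers so far. Among the measured compounds shown here, the only other measured compound, compound 1 `CC(C)C(=O)N1N=CCC1c1ccccc1`, gives 4.4, which is lower and beyond the scatter. Compound 3 `CC(C)(CN)C(=O)N1N=CCC1c1ccccc1` has not yet been measured. It differs from compound 2 on a carbonyl carbon whose other neighbours are an amide-type nitrogen in a ring: 1-(aminomethyl)-1-methylethyl in place of cyclohexyl on a carbonyl carbon. For the measured compounds named here, only one measured step bears on this change: a number 1.50 log units higher from compound 1 to compound 2 (beyond the scatter), large and beyond the scatter, with cyclohexyl in place of isopropyl on a carbonyl carbon. Cyclohexyl leaves again here, so that step points to a lower number for compound 3. The entering 1-(aminomethyl)-1-methylethyl also has nitrogen and a hydrogen-bond donor, which neither measured compound has in that group. The drop is therefore expected to exceed the measured step, though the data leave its size uncertain. The expected step is a number 3.10 log units lower from compound 2 to compound 3 (beyond the scatter). In this assay the estimated value for compound 3 is 2.8, expected to fall between 1.8 and 3.8.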

Compound 3, distribution coefficient: 1.4
For compound 3 the middle estimate is 1.40 log units above the measured one; the whole stated range lies above it.
By their numbers in this assay, from the lowest: compound 3; then compound 1; then compound 2.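

With compound 3, the group on the carbonyl carbon is seen to move the number in both directions in this assay. Aminomethyl in place of hydrogen on a saturated chain carbon gives a number 3.00 log units lower from compound 1 to compound 3 (beyond the scatter), larger in size than the opposite change with cyclohexyl in place of isopropyl, a number 1.50 log units higher from compound 1 to compound 2 (beyond the scatter). The exchange of cyclohexyl for 1-(aminomethyl)-1-methylethyl gives a number 4.50 log units lower from compound 2 to compound 3 (beyond the scatter), the widest span among the three compounds, and no measurement available here accounts for the size of these steps.

How a hydroxymethyl group, a carboxylic acid or a longer aminoalkyl chain in place of the aminomethyl would read in this assay remains open, so the compounds shown cannot tie the step to the amine rather than to another substituent at that carbon. On these data alone, it is also open whether aminomethyl placed on a cyclohexyl group would give a step of similar size, since the aminomethyl step is known only from the isopropyl group of compound 1.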